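Chain extension from compound 2 to compound 3

The source may hold more compounds than are shown below. What is called first, only, known or untested is meant among the compounds shown, and "the series" means these compounds.

- compound 1 `CN(C)CCCn1c(N)c(-c2nc3ccccc3[nH]2)c2nc(C#N)c(C#N)nc21`: 25900 nM
- compound 2 `CN(C)CCCn1c(N)c(-c2nc3ccccc3o2)c2nc(C#N)c(C#N)nc21`: 11200 nM

In a functional assay on HeLa cells (Homo sapiens) for antiproliferative activity, read by MTT assay, with a stated time of 48 h (on this read-out higher numbers stand for weaker inhibition and lower numbers for stronger inhibition), compound 2 holds the lower of the two numbers. Compound 3 `CN(C)CCCCn1c(N)c(-c2nc3ccccc3o2)c2nc(C#N)c(C#N)nc21` differs from it by (dimethylamino)methyl in place of dimethylamino on a saturated chain carbon, three bonds along the chain from an aromatic nitrogen, which turns 3-(dimethylamino)propyl into 4-(dimethylamino)butyl. For the measured compounds named here, the only measured step, a 2.3-fold lower number from compound 1 to compound 2 (0.36 log units; beyond the scatter), is modest and replaces 1H-benzimidazol-2-yl with 1,3-benzoxazol-2-yl on an aromatic carbon. Going by the values given here, it leaves the chain untouched, and no measured step covers chain length. No step beyond the scatter is therefore expected in this assay, in either direction. The expected change is a 1.1-fold lower number from compound 2 to compound 3 (0.03 log units; within the scatter). Compound 3 is estimated at 10500 nM, with a range of 4500 nM to 24000 nM.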

Compound 3, half-maximal inhibitory concentration: 1950 nM
Estimate against measurement, compound 3: 5.4-fold (0.73 log units) above; the whole stated range lies above it.
By their numbers in this assay, from the lowest: compound 3; then compound 2; then compound 1.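

The chain is now shown to matter in this assay: 4-(dimethylamino)butyl in place of 3-(dimethylamino)propyl gives a 5.7-fold lower number from compound 2 to compound 3 (0.76 log units; beyond the scatter). For the compounds shown here, the earlier pair changed only the group on the aromatic carbon, so this is the first sign that chain length alone can move the number beyond the scatter. Nothing available accounts for this step.

Two chain lengths define no trend, so a longer chain such as 5-(dimethylamino)pentyl could extend or reverse the step. Also open, going by these compounds, is whether the same step holds with 1H-benzimidazol-2-yl, or with a morpholine in place of dimethylamino.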